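A few compounds are considered here, and "the series" means these few. Any claim that something is new, unique, unknown or untested is made for them only; others in the source may bear on it.

Of the compounds shown here, three sharing one core have been measured in a functional assay on A549 cells (Homo sapiens) for cytotoxicity, read by MTT assay, with a stated time of 72 h; on this read-out lower numbers stand for stronger inhibition and higher numbers for weaker inhibition. Compound 1 `CN(C)CCn1cnnc1-c1cc(Oc2ccc(NC(=O)N/N=C/c3cccc(O)c3)cc2F)ccn1` carries a 3-hydroxyphenyl on the carbon with a double bond to nitrogen, and in this assay compound 1 reaches only the limit > 100000 nM. Compound 3 `CN(C)CCn1cnnc1-c1cc(Oc2ccc(NC(=O)N/N=C/c3ccc(O)c(O)c3)cc2F)ccn1` carries a 3,4-dihydroxyphenyl there, and in this assay compound 3 likewise reaches only the limit > 100000 nM. Within the data shown here, compound 2 `CN(C)CCn1cnnc1-c1cc(Oc2ccc(NC(=O)N/N=C/c3cccc(Cl)c3Cl)cc2F)ccn1`, with a 2,3-dichlorophenyl, is the only one with a number: in this assay compound 2 gives 1090 nM. Compound 3 therefore stands alongside compound 1 on the shared limit (the limit of > 100000 nM in this assay, at which 2 of the 3 values shown sit), separated from compound 2 by an at least 91-fold higher number from compound 2 to compound 3 (1.96 log units; beyond the scatter), while a step that the two limits leave unreadable from compound 1 to compound 3.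

Compound 4 `Cc1cc(/C=N/NC(=O)Nc2ccc(Oc3ccnc(-c4nncn4CCN(C)C)c3)c(F)c2)cc(C)c1O` differs from compound 3 by 4-hydroxy-3,5-dimethylphenyl in place of 3,4-dihydroxyphenyl on a carbon with a double bond to nitrogen. Among the measured compounds shown here, the steps that bear on this change are an at least 91-fold lower number from compound 1 to compound 2 (1.96 log units; beyond the scatter) and an at least 91-fold higher number from compound 2 to compound 3 (1.96 log units; beyond the scatter), both large and both placing the hydroxyphenyl analogues at the limit. Compound 4 keeps a hydroxy group, as compound 1 and compound 3 do. The expected step is accordingly an at least 2.0-fold lower number from compound 3 to compound 4 (0.30 log units; that floor lies within the scatter), with compound 4 expected to remain close to the limit. The estimate for compound 4 in this assay is 50000 nM, with a range from 5000 nM to 200000 nM.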

Compound 4, half-maximal inhibitory concentration: 1640 nM
Estimate against measurement, compound 4: 30-fold (1.48 log units) above, and the stated range ends above it.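

At this place, on a carbon with a double bond to nitrogen, a hydroxy group on the phenyl ring does not by itself hold a compound at the limit in this assay: 4-hydroxy-3,5-dimethylphenyl in place of 3,4-dihydroxyphenyl brings an at least 60-fold lower number from compound 3 to compound 4 (1.78 log units; beyond the scatter), and in place of 3-hydroxyphenyl it brings an at least 60-fold lower number from compound 1 to compound 4 (1.78 log units; beyond the scatter). The dichlorinated ring is also not the only group shown to give a measurable number, since 4-hydroxy-3,5-dimethylphenyl in place of 2,3-dichlorophenyl brings a 1.5-fold higher number from compound 2 to compound 4 (0.18 log units; within the scatter), so the earlier split between hydroxyphenyl and chlorinated analogues no longer holds, with compound 4 going against it. The two large steps to the new compound are bounded on one side only, and the other two hydroxyphenyl analogues remain limits rather than numbers: the limit of > 100000 nM in this assay, at which 2 of the 4 values shown sit.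

The compounds shown do not separate the contribution of the two methyl groups from that of the single hydroxy group, as both differ at once between the groups compared. As far as these compounds go, how a 3,5-dimethylphenyl without the hydroxy, or one carrying a methoxy or an amine in its stead, would read in this assay remains open.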